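Moving from an amino ester to a plain propyl ether

The compounds below may be only part of what the source reports. "The series", "measured", "known", "first", "only" and "open" are said of these compounds alone.

Measured compounds:
Compound 1, `CN(C)CC(=O)OCc1c(F)c(N)c2c(=O)cc(-c3ccc(N)c(F)c3)oc2c1F`: 9200 nM
Compound 2, `CN(C)CCCC(=O)OCc1c(F)c(N)c2c(=O)cc(-c3ccc(N)c(F)c3)oc2c1F`: 4500 nM

Both were tested in a functional assay on HeLa cells (Homo sapiens) for cytotoxicity, read by neutral red uptake, with a stated time of 3 days; on this read-out lower numbers stand for stronger inhibition and higher numbers for weaker inhibition. Going by the values given here, compound 2 gives the lower of the two numbers, and the only measured step, a 2.0-fold lower number from compound 1 to compound 2 (0.31 log units; beyond the scatter), shows the size of that gap. Compound 3, `CCCOCc1c(F)c(N)c2c(=O)cc(-c3ccc(N)c(F)c3)oc2c1F`, has not yet been measured. It differs from compound 2 by propyl in place of (3-(dimethylamino)propyl)carbonyl on an oxygen on a saturated carbon. Among the compounds with values here, the one measured step concerns only the length of the chain carrying the dimethylamino group; the ester and the dimethylamino group themselves remain in place in both compound 1 and compound 2. Compound 3 keeps neither: the whole ester group is gone and a propyl group sits on the oxygen instead. Within the data shown here, no measured step therefore bears directly on this change, and the single step available gives no direction for it. The number for compound 3 is therefore expected to lie close to that of compound 2, with a wide range to either side. The expected step is a 1.3-fold higher number from compound 2 to compound 3 (0.12 log units; within the scatter). For compound 3 the estimate is 6000 nM, with a range from 1500 nM to 25000 nM.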

Compound 3, half-maximal inhibitory concentration: 78000 nM
Beside the measured number, compound 3's estimate is 13-fold (1.11 log units) below it; the measured number lies above the stated range.
By their numbers in this assay, from the lowest: compound 2; then compound 1; then compound 3.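

In this assay, putting propyl on this oxygen in place of the longer amino ester gives a 17-fold higher number from compound 2 to compound 3 (1.24 log units; beyond the scatter), and the same kind of change from the shorter amino ester gives an 8.5-fold higher number from compound 1 to compound 3 (0.93 log units; beyond the scatter). Going by these compounds alone, both steps point the same way and lie beyond the scatter, and both are larger than the only earlier step, a 2.0-fold lower number from compound 1 to compound 2 (0.31 log units; beyond the scatter), so what sits on this oxygen moves the number much more than the chain length within the ester did. Nothing available here accounts for this rise in the number.

Compound 3 loses the carbonyl and the dimethylamino group in a single change, so the compounds shown cannot tell whether the higher number goes with losing one of these, the other or both. A 3-(dimethylamino)propyl group on the same oxygen would keep the amine without the carbonyl, and a butanoyl group would keep the carbonyl without the amine, so these two groups could pull the two parts of the change apart.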